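Working notes: 4-methoxyphenyl to 3-methoxyphenyl

The source may hold more compounds than are shown below. What is called first, only, known or untested is meant among the compounds shown, and "the series" means these compounds.

Values in a functional assay on A549 cells (Homo sapiens) for inhibition, read by MTT assay, with a stated time of 48 h; a higher number here means a weaker inhibitor of growth, a lower number a stronger inhibitor of growth:
- compound 1 `COc1ccc2c(c1)c(C1CC(c3ccc(F)cc3)=NN1C(=O)c1ccc(OC)nc1)cn2C`: 710 nM
- compound 2 `COc1ccc(C2=NN(C(=O)c3ccc(OC)nc3)C(c3cn(C)c4ccc(OC)cc34)C2)cc1`: 450 nM
- compound 3 `COc1cccc(C2=NN(C(=O)c3ccc(OC)nc3)C(c3cn(C)c4ccc(OC)cc34)C2)c1`: not yet measured

Compound 2 cannot be told apart from compound 1 on these numbers. Within the data shown here, the one measured step, methoxy in place of fluoro on an aromatic carbon, is a 1.6-fold lower number from compound 1 to compound 2 (0.20 log units; within the scatter). The next change is 3-methoxyphenyl in place of 4-methoxyphenyl on a carbon with a double bond to nitrogen. Among the measured compounds shown here, no measured step moves a group around this aromatic ring, so the evidence is indirect. For the measured compounds named here, the only guide is that swapping the group on this ring gave a 1.6-fold lower number from compound 1 to compound 2 (0.20 log units; within the scatter), and no shift beyond the scatter is therefore expected in this assay. The expected step is a 1.2-fold higher number from compound 2 to compound 3 (0.09 log units; within the scatter). For compound 3 the estimated value is 550 nM, with an expected range of 220 nM to 1400 nM.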

Compound 3, concentration for 50% growth inhibition: 470 nM
The estimate for compound 3 lay 1.2-fold (0.07 log units) above the measured number, and the stated range covers the measured number.
By their numbers in this assay, from the lowest: compounds 2, 3 and 1 (each within the scatter of the next).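

In this assay, among these compounds, 3-methoxyphenyl in place of 4-methoxyphenyl on the carbon with a double bond to nitrogen gives a 1.0-fold higher number from compound 2 to compound 3 (0.02 log units; within the scatter) and thus provides the first measured step that shifts a group around this aromatic ring; on these numbers, the two methoxyphenyl isomers cannot be told apart. The step with 3-methoxyphenyl in place of 4-fluorophenyl at the same carbon gives a 1.5-fold lower number from compound 1 to compound 3 (0.18 log units; within the scatter) and so also fails to separate the two compounds, which leaves all three compounds shown within the scatter of one another. No measurement shown here offers an explanation for this result.

Still open, as far as these compounds go, is whether an amine or a carboxylic acid in place of methoxy on this phenyl ring would give a step beyond the scatter in this assay or would likewise leave the number within it. The compounds shown also do not tell whether a longer chain, such as butoxy in place of methoxy, would be tolerated at this carbon's phenyl ring.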